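A few compounds are considered here, and "the series" means these few. Any claim that something is new, unique, unknown or untested is made for them only; others in the source may bear on it.

Measured compounds in a functional assay on DU-145 cells (Homo sapiens) for cytotoxicity, read by sulforhodamine B assay, with a stated time of 48 h; on this read-out lower numbers stand for stronger inhibition of growth and higher numbers for weaker inhibition of growth:
Compound 1, `N#Cc1ccc(Nc2nc(Oc3ccnc4ccccc34)nc(N3CCN(C(c4ccccc4)c4ccc(Cl)cc4)CC3)n2)cc1C(F)(F)F`: > 100000 nM
Compound 2, `CC(=O)N1CCN(c2nc(Nc3ccc(C#N)c(C(F)(F)F)c3)nc(Oc3ccnc4ccccc34)n2)CC1`: > 100000 nM
Compound 3, `N#Cc1ccc(Nc2nc(Oc3ccnc4ccccc34)nc(N3CCC(Cc4ccccc4)CC3)n2)cc1C(F)(F)F`: > 100000 nM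

Compound 2 stands at a limit of this assay, not at a number. Compound 1 also sits at a limit. Compound 3 sits at a limit as well. Nothing sets the three apart on the numbers shown, since all of them meet the limit of > 100000 nM in this assay, at which 3 of the 3 values shown sit, and none gives a concentration for total growth inhibition below it.

Compound 4, `COc1ccc(N2CCN(c3nc(Nc4ccc(C#N)c(C(F)(F)F)c4)nc(Oc4ccnc5ccccc45)n3)CC2)cc1`, is not yet measured. It differs from compound 2 in one place: 4-methoxyphenyl in place of acetyl on an amine nitrogen in a ring. Going by the values given here, no step between measured compounds is available here, so the size of this change cannot be read from a neighbouring pair. Given that compound 1 and compound 3 carry large groups on the same kind of ring nitrogen and still sit at the limit, the step from compound 2 to compound 4 is expected to be a number no higher from compound 2 to compound 4 (the limit leaves the size open), that is none beyond the scatter. Compound 4 is therefore expected to give about 100000 nM in this assay, within a range of 30000 nM to 200000 nM, most likely reported as a limit.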

Compound 4, concentration for total growth inhibition: > 100000 nM
Compound 4 was reported as a limit (the forecaster's own chance of this, stated with the estimate: 85%); the middle value sits exactly at the limit.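

No step can be read from compound 2 to compound 4, as both values are limits and not numbers: the limit of > 100000 nM in this assay, at which 4 of the 4 values shown sit.

The compounds shown leave open whether any group on the ring nitrogen would bring the concentration for total growth inhibition down to a readable number.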